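The source may hold more compounds than are shown below. What is called first, only, known or untested is meant among the compounds shown, and "the series" means these compounds.

Working notes on the series in an assay for inhibition of Nicotinamide phosphoribosyltransferase (Mus musculus), read by fluorescence, with a stated time of 1 h, in the presence of a further agent that is not named here; a higher number here means a weaker inhibitor, a lower number a stronger inhibitor. Among the compounds with values here, compound 3 `O=C(NCCCCCCCn1cc(-c2cccnc2)nn1)c1ccccc1-c1c[nH]nn1` gives 42.5 nM and stands second highest of the three numbers so far. Its nearest neighbour is compound 1 `O=C(O)c1ccccc1-c1ccccc1C(=O)NCCCCCCCn1cc(-c2cccnc2)nn1`, which gives 38.5 nM; the change a 1.1-fold higher number from compound 1 to compound 3 (0.04 log units; within the scatter) is within the scatter. Compound 2 `NC(=O)c1ccccc1-c1ccccc1C(=O)NCCCCCCCn1cc(-c2cccnc2)nn1` gives 87.9 nM and is the furthest; the change a 2.1-fold lower number from compound 2 to compound 3 (0.32 log units; beyond the scatter) is modest. Between the two measured neighbours, the change a 2.3-fold higher number from compound 1 to compound 2 (0.36 log units; beyond the scatter) is likewise modest.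

The next compound, compound 4 `O=C(NCCCCCCCn1cc(-c2cccnc2)nn1)c1ccccc1-n1cc(CN2CCCC2)nn1`, differs from compound 3 in one place: 4-((pyrrolidin-1-yl)methyl)-1H-1,2,3-triazol-1-yl in place of 1H-1,2,3-triazol-4-yl on an aromatic carbon. The two measured steps that touch this position, a 1.1-fold higher number from compound 1 to compound 3 (0.04 log units; within the scatter) and a 2.1-fold lower number from compound 2 to compound 3 (0.32 log units; beyond the scatter), are both small, so this position has so far tolerated a change of the aromatic group with little movement in the number. A step of similar size, in either direction or none beyond the scatter, is expected. For compound 4 the estimate in this assay is 45 nM with a range of 15 nM to 150 nM. The expected step is a 1.1-fold higher number from compound 3 to compound 4 (0.02 log units; within the scatter).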

Compound 4, half-maximal inhibitory concentration: 25.4 nM
Beside the measured number, compound 4's estimate is 1.8-fold (0.25 log units) above it, and the stated range covers the measured number.
By their numbers in this assay, from the lowest: compounds 4, 1 and 3 (each within the scatter of the next); then compound 2.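

The aromatic carbon ortho to a large group also accepts 4-((pyrrolidin-1-yl)methyl)-1H-1,2,3-triazol-1-yl in this assay: replacing 1H-1,2,3-triazol-4-yl adds a five-membered non-aromatic ring and leaves no hydrogen-bond donor on the group, yet the step stays within the scatter (a 1.7-fold lower number from compound 3 to compound 4 (0.22 log units; within the scatter)). The comparison with 2-carboxyphenyl is also within the scatter (a 1.5-fold lower number from compound 1 to compound 4 (0.18 log units; within the scatter)), while the step from 2-carbamoylphenyl is modest (a 3.5-fold lower number from compound 2 to compound 4 (0.54 log units; beyond the scatter)), so a hydrogen-bond donor on this group is not required for a number in this range. No evidence is available to explain these steps.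

Going by these compounds, it remains open whether the pyrrolidine ring matters or whether an open-chain amine or a carboxylic acid on the same methyl group would serve equally. The separate contribution of the triazole's point of attachment also remains unresolved.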